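The source may hold more compounds than are shown below. What is called first, only, known or untested is meant among the compounds shown, and "the series" means these compounds.

Measured compounds:

Compound 1 `C=CCNC(=O)/C(C)=C(\C)c1ccc(Br)cc1` gives 500 mg/kg in a toxicity assay on the whole organism (strain Icem-CET (SPF Caw)) for cytotoxicity, with Mus musculus as the target; on this read-out lower numbers stand for an effect already at smaller amounts and higher numbers for an effect only at larger amounts of compound.
Compound 2 `C/C(C(=O)NC1CC1)=C(/C)c1ccc(Br)cc1` gives 130 mg/kg in this assay.

Compound 2 stands at the lower of the two numbers, so its effect appeared at a smaller amount than that of compound 1. Among the compounds with values here, the one measured step, a 3.8-fold lower number from compound 1 to compound 2 (0.59 log units; beyond the scatter), lies beyond the scatter and concerns only the group on the amide nitrogen.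

Compound 3 `C/C(C(=O)NC1CC1)=C(/C)c1ccc(F)cc1` keeps the cyclopropyl of compound 2 and differs by fluoro in place of bromo on an aromatic carbon. No measured step concerns an exchange of one halogen for another, so nothing shown speaks directly to this change; the only step in hand does not bear on it. The expectation is therefore no step beyond the scatter in this assay, in either direction, which is what a 1.2-fold higher number from compound 2 to compound 3 (0.06 log units; within the scatter) expresses. For compound 3 the estimated value is 150 mg/kg, expected to fall between 60 mg/kg and 400 mg/kg.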

Compound 3, dose for half-maximal effect: 70 mg/kg
For compound 3 the middle estimate is 2.1-fold (0.33 log units) above the measured one; low and high end bracket the measured number.
By their numbers in this assay, from the lowest: compounds 3 and 2 (each within the scatter of the next); then compound 1.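

On the aromatic carbon para to a large group, fluoro in place of bromo gives a 1.9-fold lower number from compound 2 to compound 3 (0.27 log units; within the scatter), so in this assay this exchange of one halogen for another shows no difference that can be told from the scatter. Within the data shown here, this is the first reading at this position, and it contrasts with the one earlier change, on the amide nitrogen, where a 3.8-fold lower number from compound 1 to compound 2 (0.59 log units; beyond the scatter) stands beyond the scatter. No measured finding is available to explain the result for this position.

The two halogens are the only groups shown at this position, so it remains open whether an amine, a carboxylic acid or a plain hydrogen there would also stay within the scatter. On these data alone, it is also open whether the allyl-to-cyclopropyl step on the amide nitrogen would be of similar size with fluoro on the aromatic ring.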